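The source may hold more compounds than are shown below. What is called first, only, known or untested is meant among the compounds shown, and "the series" means these compounds.

Of the compounds shown here, three have so far been measured in a functional assay on SK-MEL-147 cells (Homo sapiens) for cytotoxicity, read by MTT assay, with a stated time of 24 h; a higher number here means that more compound is needed for the effect, a lower number that less compound is needed. Compound 1 (`CCOC(=O)c1cc([Se]Cc2ccccc2)c2cc(OC)ccc2n1`) gives 40700 nM, compound 2 (`CCOC(=O)c1cc([Se]c2ccccc2)c2cc(Br)ccc2n1`) gives 12400 nM, and compound 3 (`CCOC(=O)c1cc([Se]Cc2ccccc2)c2cc(Cl)ccc2n1`) gives 84500 nM, the highest number of the three and beyond the scatter of both others. Compound 4 (`CCOC(=O)c1cc([Se]Cc2ccccc2)c2cc(Br)ccc2n1`) has not yet been measured and differs from compound 3 in one place: bromo in place of chloro on an aromatic carbon. In words, this is bromo in place of chloro on an aromatic carbon. Among the compounds with values here, no measured pair compares bromo with chloro directly. Within the data shown here, the only measured step at this aromatic carbon is a 2.1-fold higher number from compound 1 to compound 3 (0.32 log units; beyond the scatter), with chloro in place of methoxy, and it is modest. A swap between the two halogens is therefore expected to produce a step no larger than that one, and probably a small one toward a lower number. The estimated change is a 1.3-fold lower number from compound 3 to compound 4 (0.11 log units; within the scatter), which is expected to stay within the scatter. For compound 4 the estimated value in this assay is 65000 nM, with an expected range from 30000 nM to 130000 nM.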

Compound 4, half-maximal effective concentration: 31200 nM
Compound 4: middle estimate off by 2.1-fold (0.32 log units), on the high side; measured number inside the range.
By their numbers in this assay, from the lowest: compound 2; then compounds 4 and 1 (each within the scatter of the next); then compound 3.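

In this assay, within the data shown here, the first direct comparison of the two halogens at this aromatic carbon shows that they are not interchangeable (a 2.7-fold lower number from compound 3 to compound 4 (0.43 log units; beyond the scatter)), while bromo and methoxy cannot be told apart there (a 1.3-fold lower number from compound 1 to compound 4 (0.12 log units; within the scatter)). Among the three groups compared at this carbon, chloro alone therefore stands apart from the other two, with the higher number. Among these compounds, compound 4 also provides the first one-place comparison at the selenium, where benzyl in place of phenyl brings a modest rise (a 2.5-fold higher number from compound 2 to compound 4 (0.40 log units; beyond the scatter)).

Nothing available here accounts for any of these steps. From the compounds shown here alone, it remains open how a fluoro or an amine at this aromatic carbon would read, and whether the step from phenyl to benzyl on the selenium would hold with chloro or methoxy on the ring.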